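The source may hold more compounds than are shown below. What is called first, only, known or untested is meant among the compounds shown, and "the series" means these compounds.

Measured compounds in a physicochemical assay, read by spectrophotometry, with a stated time of 60 min, tested at 100 uM; on this read-out lower numbers stand for less inhibition and higher numbers for more inhibition at the one concentration tested (going by the name of the read-out):

- compound 1, `O=c1oc2ccc(Br)cc2cc1-c1ccc(O)c(O)c1`: 80%
- compound 2, `COc1ccc(-c2c(C)c3cc(Br)ccc3oc2=S)cc1OC`: 21%

Compound 2 stands lowest of the two numbers in this assay. Going by the values given here, its nearest neighbour is compound 1, which lies higher by a margin beyond the scatter; no single-point step between these two is defined, so only the two values themselves are compared.

Compound 3, `COc1ccc(-c2c(C)c3cc(Cl)ccc3oc2=S)cc1OC`, is not yet measured. It differs from compound 2 by chloro in place of bromo on an aromatic carbon. Among the compounds with values here, no measured pair isolates this change, so its size is unknown from these data; one exchange of one halogen for another at the same place is expected to move this assay little, in no settled direction, and most likely not beyond the scatter.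

Compound 3 is therefore expected to give about 20% in this assay, with a range from 8% to 35%, the step of a number 1 percentage points lower from compound 2 to compound 3 (within the scatter) being estimated as close to none.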

Compound 3, a percentage reported as inhibition, at one concentration (the size of the read-out at that concentration, not a potency): 9%
Compound 3: middle estimate off by 11 percentage points, on the high side; the range from low to high includes it.
By their numbers in this assay, from the lowest: compound 3; then compound 2; then compound 1.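

In this assay chloro in place of bromo on the aromatic carbon gives a number 12 percentage points lower from compound 2 to compound 3 (beyond the scatter) and so shows that this position is not silent: exchanging one halogen for another is enough on its own to move the read-out beyond the scatter. Within this one pair, the bromo compound sits on the higher side, though a single pair sets no trend for the halogens at this place. Nothing measured here accounts for the step.

As far as these compounds go, whether the same exchange acts in the same direction on the core of compound 1 remains open, since only the core of compound 2 carries this pair. Also open, from the compounds shown here alone, is how a fluoro group or an amine at this place would read in this assay and whether either would extend the step or reverse it.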